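Replacing Phenyl with (Propylamino)methyl in Compound 3

The source may report more compounds than this note shows. Statements on the series, on what has been measured and on what is new or still open speak of the compounds shown alone.

Compound 1 `CC1=NN(C(=O)c2ccc([N+](=O)[O-])cc2)C(c2ccccc2O)C1` gives 30100 nM
Compound 2 `CC1=NN(C(=O)COc2ccc(Cl)cc2)C(c2cc(Br)cc(Br)c2O)C1` gives "not active" (no number reported)
Compound 3 `O=C(c1ccccc1)N1N=C(c2cc3ccccc3oc2=O)CC1c1ccccc1` gives 36600 nM

These results come from a functional assay on HepG2 cells (Homo sapiens) for cytotoxicity, read by MTT assay, with a stated time of 48 h (on this read-out lower numbers stand for stronger inhibition and higher numbers for weaker inhibition), and give only a small base for comparison. Compound 3 at 36600 nM and compound 1 at 30100 nM lie within the usual scatter of each other, so these two readings cannot be ranked. Compound 2 was reported without a number, so it has no exact place beside them.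

Compound 4 `CCCNCC(=O)N1N=C(c2cc3ccccc3oc2=O)CC1c1ccccc1` has not yet been measured. It differs from compound 3 at one place: (propylamino)methyl in place of phenyl on a carbonyl carbon. Here, (propylamino)methyl stands in place of phenyl on a carbonyl carbon, turning benzoyl into ((propylamino)methyl)carbonyl.

Among the compounds with values here, no measured pair shows this change on its own, so the size of the step cannot be read directly from the data. The expectation in this assay is therefore a cautious judgement: a modest move toward stronger inhibition, with a result inside the scatter still possible. The expected change is a 2.0-fold lower number from compound 3 to compound 4 (0.31 log units; beyond the scatter) and carries wide uncertainty. For compound 4 the estimated value is 18000 nM with an expected range from 5000 nM to 65000 nM.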

Compound 4, half-maximal inhibitory concentration: 10800 nM
Beside the measured number, compound 4's estimate is 1.7-fold (0.22 log units) above it; the range from low to high includes it.
By their numbers in this assay, from the lowest: compound 4; then compounds 1 and 3 (each within the scatter of the next).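

In this assay, within the data shown here, the group on the carbonyl carbon, whose other neighbour is the amide-type nitrogen in a ring, proves open to change: putting (propylamino)methyl in place of phenyl gives a 3.4-fold lower number from compound 3 to compound 4 (0.53 log units; beyond the scatter), the first direct reading of a change at this position. The benzoyl group is therefore not required for activity in this pair, and ((propylamino)methyl)carbonyl, which has no ring and carries one hydrogen-bond donor and one hydrogen-bond acceptor, gives stronger inhibition. No measurement at hand accounts for this gain, so its cause remains unknown.

Among these compounds, with only this one pair, it remains open whether the gain comes from the nitrogen of the new group or from the loss of the aromatic ring, a question that a plain butyl group, which holds no nitrogen, could help to separate. On these data alone, it also remains open how far the effect depends on the shape of the amine, which a longer chain such as (butylamino)methyl or a ring amine such as piperidin-1-ylmethyl on the same carbonyl carbon could test.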